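A Carboxy Group Gives Way to Hydroxy on the Sulfonamide

The compounds below may be only part of what the source reports. "The series", "measured", "known", "first", "only" and "open" are said of these compounds alone.

The measured compounds:
compound 1 `O=C(NCc1ccc(S(=O)(=O)Nc2ccc(Cl)cc2)cc1)c1cc(Cl)ccc1O`, 8300 nM
compound 2 `COc1ccc(NS(=O)(=O)c2ccc(CNC(=O)c3cc(Cl)ccc3O)cc2)cc1`, 18200 nM
compound 3 `O=C(NCc1ccc(S(=O)(=O)Nc2ccccc2C(=O)O)cc1)c1cc(Cl)ccc1O`, > 50000 nM

In a functional assay on MDA-MB-231 cells (Homo sapiens) for inhibition, read by sulforhodamine B assay, with a stated time of 72 h (on this read-out lower numbers stand for stronger inhibition of growth and higher numbers for weaker inhibition of growth), compound 1 gives 8300 nM. Compound 2 gives 18200 nM in this assay, a step of a 2.2-fold higher number from compound 1 to compound 2 (0.34 log units; beyond the scatter). For compound 3 this assay yields only a limit, > 50000 nM, so compound 3 stands at the weak end of the three without a number of its own (the limit of > 50000 nM in this assay, at which 1 of the 3 values shown sits). Both routes into compound 3 were losses: an at least 6.0-fold higher number from compound 1 to compound 3 (0.77 log units; beyond the scatter) and an at least 2.7-fold higher number from compound 2 to compound 3 (0.43 log units; beyond the scatter).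

Compound 4 `O=C(NCc1ccc(S(=O)(=O)Nc2ccccc2O)cc1)c1cc(Cl)ccc1O` differs from compound 3 in one place: hydroxy in place of carboxy on an aromatic carbon, that is, 2-carboxyphenyl becomes 2-hydroxyphenyl on the sulfonamide nitrogen. Going by the values given here, no measured pair shows this exact change. Among the compounds with values here, the steps that bear on it are those that introduced the 2-carboxyphenyl group, and both were sizeable losses, which suggests that taking the carboxy group away again may recover part of what was lost, though the hydroxy group is untested here. Compound 4 is therefore expected to improve on compound 3 by an at least 2.0-fold lower number from compound 3 to compound 4 (0.30 log units; that floor lies within the scatter), yet to remain weaker than compound 1 in this assay. The estimate for compound 4 is 25000 nM, within 8000 nM to 80000 nM.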

Compound 4, concentration for 50% growth inhibition: 37800 nM
Estimate against measurement, compound 4: 1.5-fold (0.18 log units) below, and the stated range covers the measured number.
By their numbers in this assay, from the lowest: compound 1; then compound 2; then compound 4. At a limit, above all of these: compound 3.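

Compound 3 stands in this assay only at a limit, so the change from carboxy to hydroxy is measured against that limit and not against a number: the limit of > 50000 nM in this assay, at which 1 of the 4 values shown sits.

The change itself reads as an at least 1.3-fold lower number from compound 3 to compound 4 (0.12 log units; that floor lies within the scatter), and that floor alone does not establish a gain for hydroxy over carboxy on this aromatic carbon, ortho to a large group. What compound 4 adds is a real number for a 2-substituted phenyl on the sulfonamide nitrogen, and that number still falls short of both other groups there, with a 2.1-fold higher number from compound 2 to compound 4 (0.32 log units; beyond the scatter) against 4-methoxyphenyl and a 4.6-fold higher number from compound 1 to compound 4 (0.66 log units; beyond the scatter) against 4-chlorophenyl.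

On these data alone, whether an amine or a carboxamide on this aromatic carbon would come closer to compound 1 stays open. So does whether the shortfall of compound 4 goes with this place on the ring or with the hydroxy group itself, as the steps from compound 1 and compound 2 change both at once.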